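The source may report more compounds than this note shows. Statements on the series, on what has been measured and on what is new or still open speak of the compounds shown alone.

Measured so far: compound 1 `Cn1nnnc1SCC(=O)Nc1ccc(-c2nc(-c3ccccc3)c(-c3ccccc3)n2C)cc1` gives 4.5 ug/mL in a functional assay on MCF7 cells (Homo sapiens) for cytotoxicity, read by MTT assay, with a stated time of 24 h; a higher number here means a weaker inhibitor, a lower number a stronger inhibitor; compound 2 `CCN1CCN(CC(=O)Nc2ccc(-c3nc(-c4ccccc4)c(-c4ccccc4)n3C)cc2)CC1` gives 80 ug/mL.

Compound 2 holds the highest of the two numbers, with compound 1 the nearer one by an 18-fold higher number from compound 1 to compound 2 (1.25 log units; beyond the scatter). Compound 3 `Cc1ccc(CN2CCN(CC(=O)Nc3ccc(-c4nc(-c5ccccc5)c(-c5ccccc5)n4C)cc3)CC2)cc1` differs from compound 2 by 4-methylphenyl in place of methyl on a saturated chain carbon bound to an amine nitrogen in a ring. Among the measured compounds shown here, no measured step changes this same part; the one step known, from compound 1 to compound 2, concerns the group on the carbonyl-bound chain carbon and was large. For compound 3 a moderate move toward a lower number is expected, a 2.0-fold lower number from compound 2 to compound 3 (0.30 log units; within the scatter), with wide uncertainty, giving an estimate of 40 ug/mL within 10 ug/mL to 150 ug/mL.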

Compound 3, half-maximal inhibitory concentration: 80 ug/mL
Compound 3: the middle estimate sits 2.0-fold (0.30 log units) below what was measured, and the stated range covers the measured number.
By their numbers in this assay, from the lowest: compound 1; then compounds 2 and 3 (each within the scatter of the next).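

In this assay, 4-methylphenyl in place of methyl on a saturated chain carbon bound to an amine nitrogen in a ring gave no change at the digits printed from compound 2 to compound 3 (within the scatter). Among the compounds shown here, this place thus took an aromatic ring without a readable shift, whereas the one earlier step, at a saturated chain carbon bound to a carbonyl carbon, was an 18-fold higher number from compound 1 to compound 2 (1.25 log units; beyond the scatter). No measurement at hand accounts for this flat result.

From the compounds shown here alone, whether a pyridine ring or a carboxylic acid at this place would shift the number stays open. So does whether any group here could bring the number down.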